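Ester to amide at the carbonyl of compound 2

The source may report more compounds than this note shows. Statements on the series, on what has been measured and on what is new or still open speak of the compounds shown alone.

Three esters on the shared core have been measured in an assay on isolated protein for inhibition of protein kinase C zeta type (Homo sapiens), with stated times of 1 h and 2.5 min, tested at 30 uM; on this read-out lower numbers stand for less inhibition and higher numbers for more inhibition at the one concentration tested (going by the name of the read-out). Compound 1 `COCCOC(=O)c1c(-c2ccc(OC)c(OC)c2)csc1N` gives 57%. Compound 2 `COc1ccc(-c2csc(N)c2C(=O)OCc2cccc(C)c2)cc1OC` gives 67%, the highest of the three numbers, though a number 10 percentage points higher from compound 1 to compound 2 (within the scatter), so it cannot be placed above compound 1. Compound 3 `COc1ccc(-c2csc(N)c2C(=O)OCc2ccc(C#N)cc2)cc1OC` gives 10%; the steps of a number 47 percentage points lower from compound 1 to compound 3 (beyond the scatter) and a number 57 percentage points lower from compound 2 to compound 3 (beyond the scatter) show that the group on the saturated chain carbon bound to an oxygen next to a carbonyl group governs the read-out strongly.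

Compound 4 `COc1ccc(-c2csc(N)c2C(=O)NCc2ccccc2)cc1OC` has not been measured. The change from compound 2 is benzylamino in place of (3-methylbenzyl)oxy on a carbonyl carbon. For the measured compounds named here, no measured step bears directly on it: every measured step keeps the ester and varies only the group on the chain carbon, and no measured compound carries an amide. The large steps to compound 3 show that this part of the molecule is sensitive, so a change at the carbonyl itself could move the number in either direction, and a loss is considered at least as likely as a gain. The expected step is therefore a number 22 percentage points lower from compound 2 to compound 4 (beyond the scatter), with a wide range. Compound 4 is estimated at 45%, between 5% and 75%.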

Compound 4, a percentage reported as inhibition, at one concentration (the size of the read-out at that concentration, not a potency): 43%
Compound 4: middle estimate off by 2 percentage points, on the high side; measured number inside the range.
By their numbers in this assay, from the lowest: compound 3; then compound 4; then compounds 1 and 2 (each within the scatter of the next).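

In this assay, for the compounds shown here, the first change at the carbonyl itself rather than on the chain carbon also moves the number: a number 24 percentage points lower from compound 2 to compound 4 (beyond the scatter), and a number 14 percentage points lower from compound 1 to compound 4 (beyond the scatter), so replacing either ester group with benzylamino gives a modest loss, smaller than the large steps to compound 3, and compound 4 at 43% keeps a clearly higher number than compound 3 at 10%. The ester is therefore not required for inhibition at the one concentration tested, although both ester groups in compound 1 and compound 2 give higher numbers than benzylamino. No measurement available here explains the loss on going to the amide.

The step from compound 2 to compound 4 changes the linking atom and also removes the methyl on the ring, so its size cannot be divided between the two changes; 3-methylbenzylamino, or an unsubstituted benzyloxy group, would separate them. On these data alone, it also remains open whether the amide hydrogen matters, which N-methyl-N-benzylamino on the same carbonyl carbon would test, and how a free carboxylic acid at this position would read.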